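A few compounds are considered here, and "the series" means these few. Any claim that something is new, unique, unknown or untested is made for them only; others in the source may bear on it.

Compound 1 `COc1ccc(-n2cnc3cnc(-c4ccccc4)cc32)cc1OC`: 1600 nM
Compound 2 `COc1ccc(-n2cnc3cnc(-c4ccc(F)cc4C)cc32)cc1OC`: 15 nM

In a functional assay on HL-60 cells (Homo sapiens) for activation, read by flow cytometry, with a stated time of 4 days (a lower number here means that less compound is needed, a higher number that more compound is needed for the effect), compound 2 has the lower of the two numbers, at 15 nM. Among the measured compounds shown here, the only measured step is a 110-fold lower number from compound 1 to compound 2 (2.03 log units; beyond the scatter), and it came with 4-fluoro-2-methylphenyl in place of phenyl on an aromatic carbon. Compound 3 `COc1ccc(-n2cnc3cnc(-c4ccc(F)cc4C)cc32)cc1` keeps that group and differs from compound 2 elsewhere: hydrogen in place of methoxy on an aromatic carbon, ortho to a methoxy group. The large measured step lies at another place, so it gives only a loose sense of how far numbers can move in this series. For the measured compounds named here, no measured step shows the loss of a methoxy. A moderate step towards a higher number is therefore expected, though none beyond the scatter remains possible. The estimated step is a 2.7-fold higher number from compound 2 to compound 3 (0.43 log units; beyond the scatter). For compound 3 the estimated value is 40 nM, with an expected range from 10 nM to 200 nM.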

Compound 3, half-maximal effective concentration: 6 nM
Compound 3: middle estimate off by 6.7-fold (0.82 log units), on the high side; the whole stated range lies above it.
By their numbers in this assay, from the lowest: compound 3; then compound 2; then compound 1.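

The step at this place shows that the methoxy group ortho to a methoxy group can be lost without a penalty: with hydrogen in its place there is a 2.5-fold lower number from compound 2 to compound 3 (0.40 log units; beyond the scatter) in this assay, modest but beyond the usual scatter. This change lies away from the 4-fluoro-2-methylphenyl group and is much smaller than a 110-fold lower number from compound 1 to compound 2 (2.03 log units; beyond the scatter). Nothing measured here explains why the number falls when this methoxy group is lost.

From the compounds shown here alone, whether the methoxy group that remains in compound 3 can also be replaced by hydrogen stays open, as does the effect of a hydroxyl group, a fluorine atom or an amine at the emptied place. Going by these compounds, it is also open whether losing this methoxy group would give a similar step with plain phenyl in place of 4-fluoro-2-methylphenyl.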